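Swapping a chlorophenyl for a cyano-fluorophenyl on a shared core

A few compounds are considered here, and "the series" means these few. Any claim that something is new, unique, unknown or untested is made for them only; others in the source may bear on it.

Compound 1 `NS(=O)(=O)CC(=O)NCCSc1nonc1/C(=N/O)Nc1cccc(Cl)c1` was tested in an assay for inhibition of Indoleamine 2,3-dioxygenase 1 (Homo sapiens), read by fluorescence, with a stated time of 24 h (on this read-out higher numbers stand for weaker inhibition and lower numbers for stronger inhibition), where compound 1 gives 10 nM. Among the three numbers recorded, compound 1 stands second highest. Compound 3 `N#CCC(=O)NCCSc1nonc1/C(=N/O)Nc1ccc(F)c(C(F)F)c1` gives 6.5 nM, which lies within the scatter of compound 1. Compound 2 `COc1nonc1/C(=N/O)Nc1ccc(F)c(Br)c1` gives 39 nM, a gap beyond the scatter. Compound 4 `N#Cc1cc(N/C(=N\O)c2nonc2SCCNC(=O)CS(N)(=O)=O)ccc1F` awaits measurement in this assay. It differs from compound 1 in one place: 3-cyano-4-fluorophenyl in place of 3-chlorophenyl on an amine nitrogen. Within the data shown here, no measured pair shows this exact change. Since compound 3 carries a fluorine-bearing ring and gives 6.5 nM, a small step with no direction beyond the scatter is expected. The step from compound 1 to compound 4 is estimated at a 1.2-fold higher number from compound 1 to compound 4 (0.08 log units; within the scatter). Compound 4 is expected to give about 12 nM, ranging from 4 nM to 35 nM.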

Compound 4, half-maximal inhibitory concentration: 39 nM
Estimate against measurement, compound 4: 3.3-fold (0.51 log units) below, and the stated range ends below it.
By their numbers in this assay, from the lowest: compounds 3 and 1 (each within the scatter of the next); then compounds 2 and 4 (each within the scatter of the next).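

In this assay, the group on the amine nitrogen proves able to shift the read-out: with the rest of the molecule unchanged, 3-cyano-4-fluorophenyl in place of 3-chlorophenyl brings a 3.9-fold higher number from compound 1 to compound 4 (0.59 log units; beyond the scatter) and so weaker inhibition. The earlier compounds shown here differed from one another in more than one place and could not isolate this position. Nothing available explains the weakening.

The compounds shown leave open whether the nitrile or the fluorine carries this step. A phenyl ring bearing only the nitrile, or only the fluorine, on the shared core would separate the two.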